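The compounds below may be only part of what the source reports. "The series", "measured", "known", "first", "only" and "open" are said of these compounds alone.

Among the compounds with values here, in an ADME assay on the whole organism (Rattus norvegicus, strain Sprague-Dawley) for pharmacokinetics, read by LC-MS, at a dose of 5 mg/kg by the oral route (a higher number here means more compound in the circulation at the dose given, a lower number less compound in the circulation), compound 2 (`Cc1nc(C)c([C@H](OC(C)(C)C)C(=O)O)c(N2CCC(C)(C)CC2)c1-c1ccc2c(c1)CCN(Cc1cccc(F)c1F)C2`) stands lowest of three related compounds at 5090 ng.h/mL on the numbers so far. Compound 1 (`Cc1nc(C)c([C@H](OC(C)(C)C)C(=O)O)c(N2CCC(C)(C)CC2)c1-c1ccc2c(c1)CCN(Cc1cccc(F)c1C)C2`) reaches 14000 ng.h/mL and compound 3 (`Cc1nc(C)c([C@H](OC(C)(C)C)C(=O)O)c(N2CCC(C)(C)CC2)c1-c1ccc2c(c1)CCN(c1nccc(-c3cnccn3)n1)C2`) reaches 15100 ng.h/mL in this assay as well. Compound 4 (`Cc1nc(C)c([C@H](OC(C)(C)C)C(=O)O)c(N2CCC(C)(C)CC2)c1-c1ccc2c(c1)CCN(c1nc3cnccc3s1)C2`) has not yet been measured and differs from compound 2 in one place (a group of 9 heavy atoms (6 carbon, 2 nitrogen, 1 sulfur; one five-membered aromatic ring with 2 hetero atoms, one six-membered aromatic ring with 1 hetero atom) in place of a group of 9 heavy atoms (7 carbon, 2 fluorine; one six-membered aromatic ring of carbon only), on an amine nitrogen in a ring), where the 2,3-difluorobenzyl leaves the amine nitrogen in a ring. The nearest guide is a 3.0-fold higher number from compound 2 to compound 3 (0.47 log units; beyond the scatter) and that change also swaps the 2,3-difluorobenzyl at this nitrogen for a group with two aromatic rings bearing hetero atoms. The other two steps fit the same picture: a 2.8-fold lower number from compound 1 to compound 2 (0.44 log units; beyond the scatter) sets compound 2 apart, and a 1.1-fold higher number from compound 1 to compound 3 (0.03 log units; within the scatter) leaves no separation between the other two. Within the data shown here, the group entering compound 4 is not the one in compound 3, and a single step is thin support, so a rise of similar or somewhat smaller size is expected. An estimated 1.9-fold higher number from compound 2 to compound 4 (0.27 log units; within the scatter) is what is expected here. The estimate for compound 4 is 9500 ng.h/mL with an expected range from 3500 ng.h/mL to 22000 ng.h/mL.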

Compound 4, area under the concentration-time curve: 6630 ng.h/mL
The estimate for compound 4 lay 1.4-fold (0.16 log units) above the measured number, and the stated range covers the measured number.
By their numbers in this assay, from the lowest: compounds 2 and 4 (each within the scatter of the next); then compounds 1 and 3 (each within the scatter of the next).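

In this assay, two aromatic rings bearing hetero atoms on the amine nitrogen in a ring do not by themselves raise the number, since the new group gives no separation from the 2,3-difluorobenzyl (a 1.3-fold higher number from compound 2 to compound 4 (0.11 log units; within the scatter)). The two hetero-atom groups seen at this nitrogen are also not interchangeable (a 2.3-fold lower number from compound 3 to compound 4 (0.36 log units; beyond the scatter)). The new group likewise falls short of the methyl-bearing benzyl group (a 2.1-fold lower number from compound 1 to compound 4 (0.32 log units; beyond the scatter)), so the earlier rise with compound 3 belongs to that particular group and not to hetero-aromatic groups in general.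

As far as these compounds go, whether a single pyridine ring or an amide at this nitrogen would fall with compound 3 or with compound 2 remains open. Nothing shown here gives a reason for these differences.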